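The source may hold more compounds than are shown below. What is called first, only, known or untested is meant among the compounds shown, and "the series" means these compounds.

Measured so far: compound 1 `Cc1cc(C)c(CN2CCc3c(Cl)cc([C@H](CO)[C@H]4CCOC4)c(Cl)c3C2=O)c(=O)[nH]1` gives 10 nM in an assay on cells for inhibition of histone-lysine N-methyltransferase EZH2 (Homo sapiens), read by ELISA, with a stated time of 72 h; a higher number here means a weaker inhibitor, a lower number a stronger inhibitor; compound 2 `COC(c1cc(Cl)c2c(c1Cl)C(=O)N(Cc1c(C)cc(C)[nH]c1=O)CC2)C1CCS(=O)(=O)CC1` gives 430 nM; 18 nM (2 entries) in this assay.

Among the compounds with values here, compound 1 is the only compound reported with a single value in this assay; the repeated entries for compound 2 the several entries of compound 2 in this assay, 430 nM; 18 nM (2 entries) disagree with one another by more than the usual scatter. Within the data shown here, no step between measured compounds is available. Compound 3 `Cc1cc(C)c(CN2CCc3c(Cl)cc([C@H](C)CO)c(Cl)c3C2=O)c(=O)[nH]1` differs from compound 1 in one place: a group of 4 heavy atoms (3 carbon, 1 oxygen; no ring) in place of a group of 8 heavy atoms (6 carbon, 2 oxygen; one five-membered non-aromatic ring with 1 hetero atom), on an aromatic carbon, the 1-(hydroxymethyl)ethyl group taking the place of the ring-bearing group. This change is expected to give a 3.0-fold higher number from compound 1 to compound 3 (0.48 log units; beyond the scatter), a loss in potency somewhat beyond the scatter. Compound 3 is estimated at 30 nM, in a range from 8 nM to 120 nM.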

Compound 3, half-maximal inhibitory concentration: 129 nM
Compound 3: middle estimate off by 4.3-fold (0.63 log units), on the low side, outside the stated range (above it).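

In this assay the change at this aromatic carbon gives a 13-fold higher number from compound 1 to compound 3 (1.11 log units; beyond the scatter) and so counts as a large loss. Much of the potency of compound 1 goes when the 1-(hydroxymethyl)ethyl group, which has no ring, replaces the group bearing the five-membered non-aromatic ring. No measurement shown gives a cause for this loss. Still open, on these data alone, is whether the ring oxygen matters or the ring carbons alone suffice, and how a cyclopentyl ring, a ring amine or a longer chain would fare at this position.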